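The source may hold more compounds than are shown below. What is called first, only, known or untested is meant among the compounds shown, and "the series" means these compounds.

The measured compounds:

Compound 1 `CCCn1c(=O)c2c(nc(-n3cc(I)cn3)n2Cc2ccccc2)n(CCC)c1=O`. In an in vitro assay on HEK293 cells for displacement of a labelled ligand from adenosine receptor A2b (Homo sapiens) (a lower number here means a stronger inhibitor, a higher number a weaker inhibitor), compound 1 gives a limit only, > 5800 nM.

Compound 2 `CCCn1c(=O)c2nc(-c3cnn(Cc4ccc(F)cc4F)c3)[nH]c2n(CCC)c1=O`. In this assay compound 2 gives 700 nM.

Compound 3 `CCCn1c(=O)c2nc(-n3cccn3)[nH]c2n(CCC)c1=O`. In this assay compound 3 again gives a limit, > 5800 nM.

Among the measured compounds shown here, compound 2 therefore stands as the only measured number among the three; the other two compounds sit at the limit of > 5800 nM in this assay, at which 2 of the 3 values shown sit. For the measured compounds named here, no pair of measured compounds differs in a single place, so nothing measured here sets the scale for a small change on the shared core.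

Compound 4 `CCCn1c(=O)c2nc(-c3cnn(Cc4c(F)cc(F)cc4F)c3)[nH]c2n(CCC)c1=O` differs from compound 2 by fluoro in place of hydrogen on an aromatic carbon. Going by the values given here, with no measured step of this kind to lean on, the account expects a step in this assay of modest size, within or only just beyond the scatter, in either direction. Compound 4 is accordingly expected to give 700 nM, lying between 250 nM and 2500 nM. The step expected from this change is estimated as no change at the digits printed from compound 2 to compound 4 (within the scatter).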

Compound 4, inhibition constant: 650 nM
Beside the measured number, compound 4's estimate is 1.1-fold (0.03 log units) above it, within the range that was stated.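

Among the compounds shown here, the only step that can be read on the shared core comes from the 2,4-difluorobenzyl to 2,4,6-trifluorobenzyl change, which in this assay gives a 1.1-fold lower number from compound 2 to compound 4 (0.03 log units; within the scatter). A fluoro group on this aromatic carbon, ortho to a large group, is thus tolerated, and compound 2 and compound 4 cannot be told apart in this assay. Nothing shown here bears on why this is so.

The compounds shown leave open whether a larger group at this same place, such as chloro, methoxy or an amine, would be tolerated as well. They also leave open how a plain benzyl group, carrying no fluoro groups at all, would compare with compound 2 in this assay.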